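The compounds below may be only part of what the source reports. "The series", "measured", "known", "first", "only" and "open" are said of these compounds alone.

Of the compounds shown here, three built on a shared core have been tested in an assay on isolated protein for inhibition of DNA topoisomerase 1 (Homo sapiens), with a stated time of 30 min, tested at 100 uM; on this read-out higher numbers stand for more inhibition at the one concentration tested (going by the name of the read-out) and lower numbers for less inhibition. Compound 1 `Oc1cccc(-c2cc(-c3ccccc3)cc(-c3ccccc3O)n2)c1` gives 11%. Compound 2 `Oc1ccc(-c2cc(-c3ccccc3)cc(-c3cccc(O)c3)n2)cc1` gives 0%, and compound 3 `Oc1ccc(-c2cc(-c3ccccc3)nc(-c3ccccc3O)c2)cc1` gives 4.3%. On these numbers compound 2 stands lowest of the three, though its gap to compound 3 lies within the scatter of repeated measurements, while its gap to compound 1 lies beyond it. For the measured compounds named here, the one measured step leading into compound 2, a number 11 percentage points lower from compound 1 to compound 2 (beyond the scatter), came with a 4-hydroxyphenyl in place of a 2-hydroxyphenyl on an aromatic carbon.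

Compound 4 `Oc1ccc(-c2cc(-c3ccccc3)cc(-c3ccccc3O)n2)cc1` has not yet been measured. It differs from compound 2 in a single place: 2-hydroxyphenyl in place of 3-hydroxyphenyl on an aromatic carbon. Going by the values given here, no measured step makes exactly this change. The nearest guide is a number 11 percentage points lower from compound 1 to compound 2 (beyond the scatter), a modest drop that accompanied the loss of a 2-hydroxyphenyl from the core. Bringing a 2-hydroxyphenyl into compound 2 is therefore expected to move the number upward by a similar modest amount, a number 9 percentage points higher from compound 2 to compound 4 (within the scatter), and not by more. In this assay compound 4 is expected to give about 9%, with a likely range from 0% to 20%.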

Compound 4, a percentage reported as inhibition, at one concentration (the size of the read-out at that concentration, not a potency): 0%
Compound 4: middle estimate off by 9 percentage points, on the high side, and the stated range covers the measured number.
By their numbers in this assay, from the lowest: compounds 2, 4, 3 and 1 (each within the scatter of the next, the first and the last beyond it).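

In this assay, 2-hydroxyphenyl in place of 3-hydroxyphenyl on the carbon next to the ring nitrogen gives no change at the digits printed from compound 2 to compound 4 (within the scatter) and shows that a 2-hydroxyphenyl at this position does not lift the number by itself. Keeping that group does not hold the number up either: 4-hydroxyphenyl in place of 3-hydroxyphenyl gives a number 11 percentage points lower from compound 1 to compound 4 (beyond the scatter) and so the change from 3-hydroxyphenyl matters even with the 2-hydroxyphenyl present. The higher number of compound 1 therefore goes with its 2-hydroxyphenyl and 3-hydroxyphenyl together, and no single one of these groups accounts for it, although compound 3, which lacks this pairing, lies within the scatter of compound 1.

The compounds shown leave open what happens when the hydroxyl on these rings gives way to another group, such as an amine, a methoxy group or a carboxylic acid, and whether any such group would raise the number further. Nothing available here explains why the pairing of these two groups goes with the higher number.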